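A few compounds are considered here, and "the series" means these few. Any claim that something is new, unique, unknown or untested is made for them only; others in the source may bear on it.

Compound 1 `COc1ccccc1Oc1c(N)nc(-c2ccccc2)nc1OCCO`: 31100 nM
Compound 2 `COc1ccccc1Oc1c(N)nc(-c2cccc(F)c2)nc1OCCO`: 20900 nM
Compound 3 `COc1ccccc1Oc1c(N)nc(-c2cccc(I)c2)nc1OCCO`: not yet measured

In a functional assay on B16 cells (Mus musculus) for cytotoxicity, read by CCK-8 assay, with a stated time of 24 h (on this read-out lower numbers stand for stronger inhibition and higher numbers for weaker inhibition), compound 2 stands level with compound 1 within the scatter, as shown by a 1.5-fold lower number from compound 1 to compound 2 (0.17 log units; within the scatter). The next change is iodo in place of fluoro on an aromatic carbon, meta to a large group. Among the compounds with values here, only one measured step bears on it, a 1.5-fold lower number from compound 1 to compound 2 (0.17 log units; within the scatter), also a single change on an aromatic carbon. On these data alone, no step beyond the scatter is therefore expected in this assay, and the direction remains open. The expected step is a 1.2-fold lower number from compound 2 to compound 3 (0.09 log units; within the scatter). For compound 3 the estimate is 17000 nM, with an expected range of 7000 nM to 38000 nM.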

Compound 3, half-maximal inhibitory concentration: 20300 nM
For compound 3 the middle estimate is 1.2-fold (0.08 log units) below the measured one, within the range that was stated.
By their numbers in this assay, from the lowest: compounds 3, 2 and 1 (each within the scatter of the next).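

In this assay, iodo and fluoro on this aromatic carbon, meta to a large group, stand level, with a 1.0-fold lower number from compound 2 to compound 3 (0.01 log units; within the scatter) between them. Iodo against hydrogen reads the same way, with a 1.5-fold lower number from compound 1 to compound 3 (0.19 log units; within the scatter) at this carbon, so hydrogen, fluoro and iodo all lie within the scatter of one another here, and a much heavier halogen leaves the reading level.

On these data alone, whether an amine or a carboxylic acid on this carbon would give a step beyond the scatter stays open. No measurement at hand accounts for the level reading.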